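The compounds below may be only part of what the source reports. "The series", "measured", "known", "first", "only" and "open" are said of these compounds alone.

Working notes on the series.

Compound 1 `Cc1nn([C@H](C)c2ccc(Cl)cc2Cl)c2nc(N3CC[C@H](N4CCC[C@H]4C(N)=O)[C@H](C)C3)cnc12` is the reference point. For the measured compounds named here, in a functional assay on cells for antagonist activity at C-C chemokine receptor type 4 (Homo sapiens), read by fluorescence and calcium flux, with stated times of 2.5 s and 45 s (on this read-out higher numbers stand for weaker inhibition and lower numbers for stronger inhibition), compound 1 gives 170 nM, the lowest of the three numbers so far, but compound 2 `CC1CN(c2cnc3c(C(N)=O)nn(C(C)c4ccc(Cl)cc4Cl)c3n2)CCC1N1CCCCC1` sits within the usual scatter of it, giving 228 nM in this assay. Compound 3 `CC(c1ccc(Cl)cc1Cl)n1ncc2ncc(N3CCC(N4CCCCC4)CC3)nc21` stands clearly apart: in this assay compound 3 gives 2580 nM, a gap from compound 1 that lies beyond the scatter. Going by the values given here, no pair among the measured compounds differs in one place only, so what drives these gaps cannot be read off directly; compound 2 and compound 3 each differ from compound 1 in the shared core as well as in the saturated ring substituent.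

Compound 4 `Cc1nn([C@H](C)c2ccc(Cl)cc2Cl)c2nc(N3CC[C@H](N4CCC4)[C@H](C)C3)cnc12` is not yet measured. It departs from compound 1 at a single position: azetidin-1-yl in place of 2-carbamoylpyrrolidin-1-yl on a saturated ring carbon. The outgoing group carries the only hydrogen-bond donor at that position; the incoming azetidin-1-yl ring is four-membered rather than five-membered. Compound 2, with a plain saturated ring at a comparable position, keeps a value near compound 1, which suggests the carbamoyl is not indispensable, though its core also differs. A modest weakening is expected for compound 4, with the step of a 2.4-fold higher number from compound 1 to compound 4 (0.37 log units; beyond the scatter) judged likely to fall near the edge of the scatter. Compound 4 is thus estimated at 400 nM in this assay, within a range of 120 nM to 1500 nM.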

Compound 4, half-maximal inhibitory concentration: 58 nM
Compound 4: the middle estimate sits 6.9-fold (0.84 log units) above what was measured; measured number outside the range, below it.
By their numbers in this assay, from the lowest: compound 4; then compounds 1 and 2 (each within the scatter of the next); then compound 3.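

In this assay, azetidin-1-yl in place of 2-carbamoylpyrrolidin-1-yl gives a 2.9-fold lower number from compound 1 to compound 4 (0.47 log units; beyond the scatter) as a clean single-place comparison on the core of compound 1. This position therefore does not require the carbamoyl group, its hydrogen-bond donor or the defined stereocentre of the outgoing ring, and the smaller four-membered ring is tolerated with a gain beyond the scatter. No measured evidence bears on why the number falls, so the step stays an observation only.

As far as these compounds go, it remains open whether the gain follows the loss of the carbamoyl group or the change in ring size. A plain pyrrolidin-1-yl or a dimethylamino group at this place on the core of compound 1 would separate those two changes, and a carboxylic acid on the pyrrolidine ring would test the carbamoyl position further.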